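A few compounds are considered here, and "the series" means these few. Any claim that something is new, unique, unknown or untested is made for them only; others in the source may bear on it.

Three compounds share one core. In an ADME assay on Vero cells (Chlorocebus sabaeus) for cytotoxicity (on this read-out lower numbers stand for stronger inhibition and higher numbers for weaker inhibition), compound 1 `Cc1cccc(C)c1N1C(=O)c2cccnc2C1=O` gives 20000 nM, and compound 3 `CCCCCc1ccc(N2C(=O)c3cccnc3C2=O)cc1` gives 18000 nM; these two values lie within the scatter of each other. Compound 2 `O=C1c2nccnc2C(=O)N1Cc1ccccc1` reaches in this assay only a limit of > 100000 nM, so no number is known for it. That reading is the limit of > 100000 nM in this assay, at which 1 of the 3 values shown sits. Compound 4 `C[C@@H](c1ccccc1)N1C(=O)c2nccnc2C1=O` differs from compound 2 by methyl in place of hydrogen on a saturated chain carbon bound to an amide-type nitrogen in a ring and an aromatic carbon. Among the measured compounds shown here, no measured pair shows such a change, so in this assay the author expects no step beyond the scatter, in either direction. Compound 4 is therefore estimated at 100000 nM, between 40000 nM and 300000 nM, with a good chance that again only a limit is reported. The expected step is a number no higher from compound 2 to compound 4 (the limit leaves the size open).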

Compound 4, half-maximal inhibitory concentration: 85000 nM
Estimate against measurement, compound 4: 1.2-fold (0.07 log units) above, and the stated range covers the measured number.
By their numbers in this assay, from the lowest: compounds 3 and 1 (each within the scatter of the next); then compound 4. At a limit, above all of these: compound 2.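

Methyl in place of hydrogen on this saturated chain carbon gives a measured number where only a limit stood before, in this assay, with an at least 1.1-fold lower number from compound 2 to compound 4 (0.07 log units; that floor lies within the scatter). This is the only step shown at this position, and its floor does not establish a change beyond the scatter. As far as these compounds go, its true size stays open because compound 2 is known only as a limit: the limit of > 100000 nM in this assay, at which 1 of the 4 values shown sits.

The compounds shown leave open how a longer chain, a hydroxyl or an amine on this carbon would read. They also leave open whether the mirror-image form of compound 4 would give a similar number.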